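Swapping a Methyl for Two Chlorines on the Aryl Amide

A few compounds are considered here, and "the series" means these few. Any claim that something is new, unique, unknown or untested is made for them only; others in the source may bear on it.

Compound 1 `O=C(Nc1c(C(O)(C(F)(F)F)C(F)(F)F)ccc2ccccc12)C1CC1` carries a cyclopropyl group on a carbonyl carbon of the shared core, and in an assay on LtK cells with ATP-sensitive inward rectifier potassium channel 11 (Homo sapiens) as the target (a higher number here means that more compound is needed for the effect, a lower number that less compound is needed), compound 1 gives 751 nM. Compound 2 `O=C(Nc1c(C(O)(C(F)(F)F)C(F)(F)F)ccc2ccccc12)c1ccccc1` has phenyl in place of cyclopropyl on a carbonyl carbon, and in this assay compound 2 gives 44 nM, which is a 17-fold lower number from compound 1 to compound 2 (1.23 log units; beyond the scatter). Compound 3 `Cc1cccc(C(=O)Nc2c(C(O)(C(F)(F)F)C(F)(F)F)ccc3ccccc23)c1` has 3-methylphenyl there instead; in this assay compound 3 gives 23 nM, which is a 33-fold lower number from compound 1 to compound 3 (1.51 log units; beyond the scatter). Compound 3 has the lowest number shown, but a 1.9-fold lower number from compound 2 to compound 3 (0.28 log units; within the scatter), so compounds 2 and 3 stand together.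

Compound 4 `O=C(Nc1c(C(O)(C(F)(F)F)C(F)(F)F)ccc2ccccc12)c1ccc(Cl)c(Cl)c1` is not yet measured. Its change from compound 3 is 3,4-dichlorophenyl in place of 3-methylphenyl on a carbonyl carbon. Within the data shown here, the only measured step that alters the groups on the aryl ring is methyl in place of hydrogen on an aromatic carbon, and that stayed within the scatter. The large steps from cyclopropyl to an aryl ring do not bear here, since compound 4 keeps the aryl ring. A step within the scatter is therefore expected: a 1.1-fold higher number from compound 3 to compound 4 (0.04 log units; within the scatter). Compound 4 is estimated at 25 nM, with a range from 8 nM to 80 nM.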

Compound 4, half-maximal effective concentration: 194 nM
Compound 4: the middle estimate sits 7.8-fold (0.89 log units) below what was measured; measured number outside the range, above it.
By their numbers in this assay, from the lowest: compounds 3 and 2 (each within the scatter of the next); then compound 4; then compound 1.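

The groups on this aryl ring do matter in this assay: going to 3,4-dichlorophenyl gives an 8.4-fold higher number from compound 3 to compound 4 (0.93 log units; beyond the scatter) and also a 4.4-fold higher number from compound 2 to compound 4 (0.64 log units; beyond the scatter), so this change moves the number beyond the scatter, which the added methyl did not. Keeping an aryl ring on the carbonyl carbon therefore does not by itself hold the number low, although the dichlorinated ring still shows a 3.9-fold lower number from compound 1 to compound 4 (0.59 log units; beyond the scatter) over the cyclopropyl group. Nothing available here accounts for the rise seen with the two chlorines.

The compounds shown do not separate the two chlorines, and a 3-chlorophenyl or a 4-chlorophenyl group on the carbonyl carbon would show whether one alone produces the rise. As far as these compounds go, whether a methoxy group or a nitrile on the ring would behave like the methyl or like the chlorines also stays open.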